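Cyclopentylsulfanyl for cyclohexylamino on the shared core

The compounds below may be only part of what the source reports. "The series", "measured", "known", "first", "only" and "open" are said of these compounds alone.

Measured so far:
compound 1 `Nc1nc(NC2CCCCC2)c2ncn(/C=C3/CC3(CO)CO)c2n1` — > 20000 nM
compound 2 `CCOc1nc(N)nc2c1ncn2/C=C1/CC1(CO)CO` — > 20000 nM

Compound 1 stands only at a limit of an ADME assay on BCBL1 cells (Homo sapiens) for cytotoxicity, with a stated time of 7 days; a lower number here means that less compound is tolerated, a higher number that more compound is tolerated: in this assay compound 1 gives > 20000 nM, which is a limit and not a number. Compound 2 likewise gives > 20000 nM in this assay, again a limit. Going by the values given here, the single measured step, a step that the two limits leave unreadable from compound 1 to compound 2, is unreadable because of the limit of > 20000 nM in this assay, at which 2 of the 2 values shown sit; it therefore gives no sense of how exchanging the group on that aromatic carbon of the shared core shifts tolerated concentration.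

Compound 3 `Nc1nc(SC2CCCC2)c2ncn(/C=C3/CC3(CO)CO)c2n1` differs from compound 1 by cyclopentylsulfanyl in place of cyclohexylamino on an aromatic carbon. Among the compounds with values here, no measured step bears on this change, so no shift beyond the scatter can be expected from the data; the expectation is that compound 3 also reaches the limit. Compound 3 is estimated to give 25000 nM in this assay, with a range of 10000 nM to 60000 nM. The expected step is a step that the limit leaves unreadable from compound 1 to compound 3.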

Compound 3, half-maximal cytotoxic concentration: > 20000 nM
Compound 3: only a limit was reported (the forecaster's own chance of this, stated with the estimate: 70%); the middle value does not contradict the limit.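

The steps among compound 1, compound 2 and compound 3 in this assay cannot be read, because all three values are limits: the limit of > 20000 nM in this assay, at which 3 of the 3 values shown sit.

The compounds shown leave open how far the group on that aromatic carbon shifts tolerated concentration, and at what concentration any of the three becomes cytotoxic.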